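This account rests on a few compounds, and the source may have more. Where it says the series, first, only, none or still open, it means among the compounds named here.

Working notes on the series, cytotoxicity in an ADME assay on L1210/0 cells (Mus musculus) for cytotoxicity, with a stated time of 48 h; a lower number here means a stronger inhibitor, a higher number a weaker inhibitor.

Within the data shown here, compound 1 `[N-]=[N+]=NCc1cn([C@H]2C[C@H](O)[C@@H](CO)O2)c(=O)[nH]c1=O` is the one member with a number in this assay: compound 1 gives 124000 nM. Compound 2 `O=c1ccn(C[C@@H]2C[C@H](CO)c3ccccc32)c(=O)[nH]1` reaches only the limit of the measurement, so compound 2 gives > 200000 nM. Compound 3 `O=c1[nH]cnc2c1nnn2CC1CCC(CO)C1` likewise stops at the limit, so compound 3 gives > 200000 nM. Among the measured compounds shown here, compound 1 therefore stands as the only measured number, with the two other entries sitting at the limit of > 200000 nM in this assay, at which 2 of the 3 values shown sit. For the measured compounds named here, no two measured compounds differ in a single place, so no measured step is available in this assay.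

Compound 4 `O=c1[nH]c(=O)n([C@H]2C[C@H](O)[C@@H](CO)O2)cc1/C=C/Cl` is the next compound to be run in this assay. Its change from compound 1 is 2-chloroethenyl in place of azidomethyl on an aromatic carbon. Both the leaving and the entering group sit on the shared core of compound 1, on an aromatic carbon of a six-membered aromatic ring with 2 nitrogen, two atoms from the ring nitrogen. Going by the values given here, with no measured step to lean on, the expected step is a 1.2-fold higher number from compound 1 to compound 4 (0.08 log units; within the scatter), not beyond the scatter in either direction. Compound 4 is accordingly estimated to give 150000 nM in this assay, within 50000 nM to 400000 nM. A real chance remains that the readout for compound 4 ends at the limit rather than at a number.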

Compound 4, half-maximal inhibitory concentration: > 200000 nM
Compound 4: a limit, no number; the forecaster's own chance of this, stated with the estimate: 40%; middle value at least 1.3-fold (0.12 log units) away from the limit.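

Among these compounds, replacing azidomethyl with 2-chloroethenyl on this aromatic carbon, two atoms from the ring nitrogen, gives the first readable step in this assay: an at least 1.6-fold higher number from compound 1 to compound 4 (0.20 log units; that floor lies within the scatter). The step has only a floor, as the readout for compound 4 is a limit of the assay and not a number, so the change is not shown to separate the two compounds beyond the scatter. Among the compounds shown here, the result does show that this position can carry a group of 3 heavy atoms with no hydrogen-bond acceptor and still give no number in this assay, leaving compound 1 as the only member with one, while most of the series now sits at the ceiling: the limit of > 200000 nM in this assay, at which 3 of the 4 values shown sit.

For the compounds shown here, the true size of this step remains unknown, and with only two groups compared at this position, no trend can be drawn from it. As far as these compounds go, whether an amine, a carboxylic acid or a longer alkyl chain on this aromatic carbon would give a number in this assay, and on which side of compound 1 that number would fall, remains open.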